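Swapping an oxazolyl ether for a triazolyl thioether

The compounds below may be only part of what the source reports. "The series", "measured", "known", "first", "only" and "open" are said of these compounds alone.

Compound 1 `CCOC(=O)c1c(C)noc1OCC(=O)[C@H](CC(=O)O)NC(=O)[C@@H](NC(=O)COc1cccc2ccccc12)C(C)C`: > 200000 nM
Compound 2 `COC(=O)c1cc(OCC(=O)[C@H](CC(=O)O)NC(=O)[C@@H](NC(=O)COc2cccc3ccccc23)C(C)C)no1`: 71000 nM
Compound 3 `CC(C)[C@H](NC(=O)COc1cccc2ccccc12)C(=O)N[C@@H](CC(=O)O)C(=O)CSC1=NCCS1`: > 200000 nM

For the measured compounds named here, in a functional assay on Jurkat cells (Homo sapiens) for inhibition (on this read-out higher numbers stand for weaker inhibition and lower numbers for stronger inhibition), compound 2 gives 71000 nM, the only actual number among the three values shown. The value of compound 1 is a limit of the assay. The value of compound 3 is likewise a limit. Both sit at the limit of > 200000 nM in this assay, at which 2 of the 3 values shown sit. The measured steps are an at least 2.8-fold lower number from compound 1 to compound 2 (0.44 log units; beyond the scatter) and an at least 2.8-fold higher number from compound 2 to compound 3 (0.44 log units; beyond the scatter), while a step that the two limits leave unreadable from compound 1 to compound 3.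

Compound 4 `CC(C)[C@H](NC(=O)COc1cccc2ccccc12)C(=O)N[C@@H](CC(=O)O)C(=O)CSc1nncn1C` is not yet measured. It differs from compound 2 in that ((4-methyl-4H-1,2,4-triazol-3-yl)sulfanyl in place of (5-(methoxycarbonyl)-1,2-oxazol-3-yl)oxy on a saturated chain carbon bound to a carbonyl carbon). The step from compound 2 to compound 3 bears directly on this change: there too the oxazolyl ether gave way to a sulfur-linked five-membered heterocycle, and the number rose to the limit. Compound 4 is therefore expected to show a weakening, a 2.8-fold higher number from compound 2 to compound 4 (0.45 log units; beyond the scatter), quite possibly ending at a limit again. The estimate for compound 4 is 200000 nM, with a range from 60000 nM to 600000 nM.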

Compound 4, half-maximal inhibitory concentration: > 200000 nM
Compound 4: no number, only a limit (the forecaster's own chance of this, stated with the estimate: 60%); the middle value sits exactly at the limit.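

In this assay, placing (4-methyl-4H-1,2,4-triazol-3-yl)sulfanyl in place of (5-(methoxycarbonyl)-1,2-oxazol-3-yl)oxy on a saturated chain carbon bound to a carbonyl carbon gives an at least 2.8-fold higher number from compound 2 to compound 4 (0.44 log units; beyond the scatter). Together with compound 3, this shows that the loss from compound 2 is not confined to a non-aromatic sulfur-linked ring, since an aromatic ring on sulfur also ends without a number. The value of compound 4 is a limit, and the steps among compound 1, compound 3 and compound 4 cannot be read: the limit of > 200000 nM in this assay, at which 3 of the 4 values shown sit.

On these data alone, it remains open whether the step follows from the sulfur link, from the change of ring, or from the loss of the methoxycarbonyl. Also open, as far as these compounds go, is how an amine in place of that methoxycarbonyl on the ring of compound 2 would read out in this assay.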